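Fluoro in Place of Chloro on a Shared Core

A few compounds are considered here, and "the series" means these few. Any claim that something is new, unique, unknown or untested is made for them only; others in the source may bear on it.

compound 1 `N=C(N)c1ccc(-c2ccc(-c3cc(Cl)cc(Cl)c3)s2)s1` gives 1850 nM
compound 2 `N=C(N)c1ccc(-c2ccc(-c3ccc(Cl)cc3)s2)s1` gives 1710 nM

Both numbers come from a functional assay on RXF 393 cells (Homo sapiens) for inhibition, read by sulforhodamine B assay, with a stated time of 48 h; a lower number here means a stronger inhibitor of growth, a higher number a weaker inhibitor of growth. Compound 2 holds the numerically lower of the two, yet compound 1 sits within the scatter of it, so the two cannot be told apart. Compound 3 `N=C(N)c1ccc(-c2ccc(-c3ccc(F)cc3)s2)s1` differs from compound 2 in one place: fluoro in place of chloro on an aromatic carbon. Among the compounds with values here, no measured step of this kind exists here, so only a small shift beyond the scatter is expected, toward a higher number, as the estimated step of a 1.5-fold higher number from compound 2 to compound 3 (0.18 log units; within the scatter) shows. For compound 3 the estimated value in this assay is 2600 nM, with a likely range from 1200 nM to 5600 nM.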

Compound 3, concentration for 50% growth inhibition: 1750 nM
For compound 3 the middle estimate is 1.5-fold (0.17 log units) above the measured one, and the stated range covers the measured number.
By their numbers in this assay, from the lowest: compounds 2, 3 and 1 (each within the scatter of the next).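

In this assay, fluoro in place of chloro, on an aromatic carbon para to a large group, gives a 1.0-fold higher number from compound 2 to compound 3 (0.01 log units; within the scatter), so compound 2 and compound 3 cannot be told apart. Within the data shown here, this is the only single-place step here, and it shows that this position accepts either halogen without a readable difference. Nothing available explains this outcome. Going by these compounds, whether an amine or a carboxylic acid at this position would also stay within the scatter of compound 2 remains open, as does the effect of a plain hydrogen there.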